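From Amino to Methanesulfonamido: Expecting Little Change

The source may report more compounds than this note shows. Statements on the series, on what has been measured and on what is new or still open speak of the compounds shown alone.

Measured so far:
compound 1 `Cc1cc2c(c(N)nn2C)c(=O)[nH]1` gives 5%
compound 2 `Cn1nc(N)c2c(=O)[nH]c(-c3ccccn3)cc21` gives 9%

In an assay on isolated protein for inhibition of MAP kinase-activated protein kinase 5 (Homo sapiens), read by mobility shift assay, tested at 30 uM (on this read-out lower numbers stand for less inhibition and higher numbers for more inhibition at the one concentration tested (going by the name of the read-out)), compound 1 stands lowest of the two numbers, though the step of a number 4 percentage points higher from compound 1 to compound 2 (within the scatter) is within the scatter. Compound 3 `Cc1cc2c(c(NS(C)(=O)=O)nn2C)c(=O)[nH]1` carries methylsulfonyl in place of hydrogen on a nitrogen on an aromatic ring. For the measured compounds named here, the only measured step concerns pyridin-2-yl in place of methyl on an aromatic carbon, a different place, so nothing measured bears on this change. With both measured numbers small, compound 3 is expected to show no step beyond the scatter, a number 1 percentage points higher from compound 1 to compound 3 (within the scatter). The estimate for compound 3 is 6%, within -5% to 20%.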

Compound 3, a percentage reported as inhibition, at one concentration (the size of the read-out at that concentration, not a potency): 0%
For compound 3 the middle estimate is 6 percentage points above the measured one; the measured number falls inside the stated range.
By their numbers in this assay, from the lowest: compounds 3, 1 and 2 (each within the scatter of the next).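

Compounds 1 and 2 both keep the amino group unchanged, so only compound 3 tests this nitrogen: with methylsulfonyl in place of hydrogen, this assay gives a number 5 percentage points lower from compound 1 to compound 3 (within the scatter). On the core of compound 1, this change therefore moves the number no further than the scatter. Nothing at hand bears on the reason for this result.

Still open, from the compounds shown here alone, is whether an acetyl group or a longer chain such as ethylsulfonyl on this nitrogen would give a step beyond the scatter. Going by these compounds, it is also open whether methylsulfonyl would read the same alongside the pyridin-2-yl of compound 2.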